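Ethyl for Vinyl on an Anilide Carbonyl: Two Pairs

The compounds below may be only part of what the source reports. "The series", "measured", "known", "first", "only" and "open" are said of these compounds alone.

Measured compounds:
compound 1, `CCC(=O)Nc1ccc(C(=O)Nc2ccc(C)c(Nc3nccc(-c4cccnc4)n3)c2)cc1`, a limit of the assay: > 10000 nM
compound 2, `C=CC(=O)Nc1ccc(C(=O)Nc2ccc(C)c(Nc3nccc(-c4cccnc4)n3)c2)cc1`: 5600 nM
compound 3, `C=CC(=O)Nc1cc(C(=O)Nc2ccc(C)c(Nc3nccc(-c4cccnc4)n3)c2)cc(C(F)(F)F)c1`: 5460 nM

All three were tested in an ADME assay on BaF3 cells (Mus musculus) for cytotoxicity, read by CellTiter-Glo and CCK-8 assay, with a stated time of 72 h; a lower number here means a stronger inhibitor of growth, a higher number a weaker inhibitor of growth. Compound 2 gives 5600 nM and compound 3 gives 5460 nM; these two numbers lie within the usual scatter of each other. For compound 1 the assay reports only a limit, > 10000 nM, and not a number. Compound 1 differs from compound 2 by ethyl in place of vinyl on a carbonyl carbon. That change produced an at least 1.7-fold higher number from compound 2 to compound 1 (0.25 log units; that floor lies within the scatter); the size of the step is known only as a floor because of the limit of > 10000 nM in this assay, at which 1 of the 3 values shown sits.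

Compound 4, `CCC(=O)Nc1cc(C(=O)Nc2ccc(C)c(Nc3nccc(-c4cccnc4)n3)c2)cc(C(F)(F)F)c1`, has not been measured. It differs from compound 3 by ethyl in place of vinyl on a carbonyl carbon, the same change as from compound 2 to compound 1, at the same place: a carbonyl carbon whose other neighbours are an amide-type nitrogen. How the core of compound 3 differs from the core of compound 2 is not broken down here.

Compound 4 is expected to move by a 2.2-fold higher number from compound 3 to compound 4 (0.34 log units; beyond the scatter), a step placed beside the earlier one, an at least 1.7-fold higher number from compound 2 to compound 1 (0.25 log units; that floor lies within the scatter). That expectation rests on compound 3 starting from 5460 nM, close to compound 2. Compound 4 is therefore estimated at 12000 nM, likely reported only as a limit, with an expected range from 5000 nM to 40000 nM.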

Compound 4, concentration for 50% growth inhibition: > 10000 nM
Compound 4 ended at the assay's limit; the forecaster's own chance of this, stated with the estimate: 70%; the middle value is on the limit's open side.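

In this assay compound 4 gives > 10000 nM, which is a limit of the assay and not a number. Putting ethyl in place of vinyl on the carbonyl carbon therefore gives an at least 1.8-fold higher number from compound 3 to compound 4 (0.26 log units; that floor lies within the scatter), and this is a floor rather than a measured size. What carries from one core to the other is a shared outcome: on each core the vinyl compound has a measured number and the ethyl compound sits at the limit, but the true size of the step stays unknown on both, and a real difference between the cores cannot be seen or excluded because the readings stop there: the limit of > 10000 nM in this assay, at which 2 of the 4 values shown sit.

The compounds shown leave open how far past the limit the two ethyl compounds lie, and so whether the step is the same size on both cores. They also leave open what other groups at this carbonyl would do, such as a longer chain like butanoyl or a vinyl group carrying an amine.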